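Swapping phenyl for pyrazolyl on the propyl chain

The compounds below may be only part of what the source reports. "The series", "measured", "known", "first", "only" and "open" are said of these compounds alone.

Three acylguanidines have been measured in a functional assay on Sf9 cells for antagonist activity at histamine H2 receptor (Homo sapiens), with stated times of 2 min and 20 min; a higher number here means a more potent compound, by a factor of ten per unit of this negative logarithm, a lower number a less potent compound. Compound 1 `CC(CC(=O)/N=C(\N)NCCCc1ccccc1)c1ccccc1` gives 5.89, compound 2 `N/C(=N\C(=O)CC(c1ccccc1)c1ccccc1)NCCCc1ccccc1` gives 5.89, and compound 3 `CC(CC(=O)/N=C(\N)NCCCc1ncc[nH]1)c1ccccc1` gives 5.3. Compound 2 stands level with compound 1, the two together the highest of the three numbers, and the step of no change at the digits printed from compound 1 to compound 2 (within the scatter) shows that a second phenyl on the saturated chain carbon left the result unchanged. The step of a number 0.59 log units lower from compound 1 to compound 3 (beyond the scatter) is the only one that touches the other end of the molecule, where 1H-imidazol-2-yl in place of phenyl on the saturated chain carbon three bonds from the amine nitrogen cost a modest amount.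

Compound 4 `N/C(=N\C(=O)CC(c1ccccc1)c1ccccc1)NCCCc1cn[nH]c1` is the next step from compound 2, and the difference is 1H-pyrazol-4-yl in place of phenyl on a saturated chain carbon, three bonds along the chain from an amine nitrogen. Going by the values given here, no measured step contains exactly this change, but the step from compound 1 to compound 3 replaced the same phenyl at the same place with another five-membered aromatic ring with heteroatoms, and that is the closest guide. A loss of similar size is therefore expected in this assay, so the step of a number 0.49 log units lower from compound 2 to compound 4 (beyond the scatter) is estimated to be a modest drop. Compound 4 is expected to give 5.4, with a range from 4.9 to 5.9.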

Compound 4, negative logarithm of the antagonist equilibrium constant: 5.42
Estimate against measurement, compound 4: 0.02 log units below; the range from low to high includes it.
By their numbers in this assay, from the lowest: compounds 3 and 4 (each within the scatter of the next); then compounds 1 and 2 (each within the scatter of the next).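

In this assay the exchange of phenyl for 1H-pyrazol-4-yl on the saturated chain carbon, three bonds along the chain from an amine nitrogen, gives a number 0.47 log units lower from compound 2 to compound 4 (beyond the scatter) and so extends the loss at this position to a second five-membered aromatic ring with hetero atoms and to the compound carrying two phenyl groups at the other end. Read with a number 0.59 log units lower from compound 1 to compound 3 (beyond the scatter) for 1H-imidazol-2-yl, this means that both ring replacements shown for this phenyl lower the number, with no compound here going against that, so the loss is not tied to the imidazole ring or to a single acyl end. Nothing at hand explains why the phenyl compounds stand higher.

Because compounds 3 and 4 differ in two places, the compounds shown leave open how 1H-imidazol-2-yl and 1H-pyrazol-4-yl compare on one and the same acyl end. They also leave open whether a pyridine ring, or a butyl chain in place of the propyl chain, would keep the number of compound 2 at this end of the molecule.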